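Trimming one hydroxy from a long-chain quinone ether

The compounds below may be only part of what the source reports. "The series", "measured", "known", "first", "only" and "open" are said of these compounds alone.

The measured compounds:
Compound 1 `COC1=C(OC)C(=O)C(CCCO)=C(C)C1=O` gives 13000 nM in a functional assay on HL-60 cells (Homo sapiens) for antiproliferative activity, read by MTT assay, with a stated time of 48 h; on this read-out higher numbers stand for weaker inhibition and lower numbers for stronger inhibition.
Compound 3 `COC1=C(OC)C(=O)C(CCCCCO)=C(C)C1=O` gives 13000 nM in this assay.
Compound 2 `COC1=C(OC)C(=O)C(CCCCCCCCCCOc2c(O)cc(O)cc2O)=C(C)C1=O` reaches only a limit of this assay, > 200000 nM, and no number.

Compounds 1 and 3 share the quinone core and differ only in the hydroxy-bearing chain; the step is no change at the digits printed from compound 1 to compound 3 (within the scatter), so lengthening the short chain leaves the read-out where it was. From the compounds shown here alone, compound 2 carries a much longer chain ending in an aryl ether, and it stands apart from both: it sits at the limit, (the limit of > 200000 nM in this assay, at which 1 of the 3 values shown sits), so its true value is unknown beyond that.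

Compound 4 `COC1=C(OC)C(=O)C(CCCCCCCCCCOc2cc(O)cc(O)c2)=C(C)C1=O` differs from compound 2 in one place: 3,5-dihydroxyphenyl in place of 2,4,6-trihydroxyphenyl on an oxygen on a saturated carbon. No measured pair changes this aryl group, so none of the shown steps bears directly on it; the only step available, between compound 1 and compound 3, concerns the chain and was flat. With compound 2 at a limit, the starting point itself is uncertain. Compound 4 is therefore expected to remain weak, with an estimated value of 150000 nM, in a range from 30000 nM to 400000 nM. The expected step is an at least 1.3-fold lower number from compound 2 to compound 4 (0.12 log units; that floor lies within the scatter), carrying a real chance that compound 4 also returns only a limit.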

Compound 4, half-maximal inhibitory concentration: 16000 nM
Beside the measured number, compound 4's estimate is 9.4-fold (0.97 log units) above it; measured number outside the range, below it.
By their numbers in this assay, from the lowest: compounds 1, 3 and 4 (each within the scatter of the next). At a limit, above all of these: compound 2.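

In this assay, the aryl group on the ether oxygen at the end of the long chain proves able to move the read-out by a wide margin: 3,5-dihydroxyphenyl in place of 2,4,6-trihydroxyphenyl gives an at least 12-fold lower number from compound 2 to compound 4 (1.09 log units; beyond the scatter). Within the data shown here, the only earlier step, no change at the digits printed from compound 1 to compound 3 (within the scatter), concerned the short hydroxy-bearing chain and said nothing about this aryl group, so this is the first sign that the far end of the long chain is sensitive to a small edit. Compound 2 stands at a limit and not at a number, so the size of this step is only a floor and the full change remains unknown: the limit of > 200000 nM in this assay, at which 1 of the 4 values shown sits.

The hydroxy count and the hydroxy arrangement on the ring change together in this one step, so the two compounds cannot say which of them carries the effect; a phenyl ring with a single hydroxy, or methoxy groups in place of the hydroxy groups, would help to separate them. From the compounds shown here alone, it also remains open how the aryl ether behaves on a shorter chain, and whether a carboxylic acid or an amine at this position would be tolerated.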